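Dimethylamino for Methoxy Carried onto the Hydroxy-Bearing Core

The compounds below may be only part of what the source reports. "The series", "measured", "known", "first", "only" and "open" are said of these compounds alone.

Compound 1 `COc1ccc(-c2ccc(-c3ccc(-c4nc5ccccc5[nH]4)cc3)cc2)cc1` and compound 2 `CN(C)c1ccc(-c2ccc(-c3ccc(-c4nc5ccccc5[nH]4)cc3)cc2)cc1` share one core and differ by dimethylamino in place of methoxy on an aromatic carbon. In a functional assay on A549 cells (Homo sapiens) for inhibition, read by sulforhodamine B assay (on this read-out lower numbers stand for stronger inhibition of growth and higher numbers for weaker inhibition of growth), compound 1 gives 38100 nM and compound 2 gives 30100 nM, a change of a 1.3-fold lower number from compound 1 to compound 2 (0.10 log units; within the scatter). Compound 3 `COc1ccc(-c2ccc(-c3ccc(-c4nc5c(O)cccc5[nH]4)cc3)cc2)cc1` differs from compound 1 by hydroxy in place of hydrogen on an aromatic carbon; in this assay compound 3 gives 7690 nM, which is a 5.0-fold lower number from compound 1 to compound 3 (0.69 log units; beyond the scatter). Compound 4 `CN(C)c1ccc(-c2ccc(-c3ccc(-c4nc5c(O)cccc5[nH]4)cc3)cc2)cc1` stands to compound 3 as compound 2 stands to compound 1: the change is dimethylamino in place of methoxy on an aromatic carbon, the same change at the same place, now carried onto the core of compound 3. The measured instance of this change reads a 1.3-fold lower number from compound 1 to compound 2 (0.10 log units; within the scatter) and stayed within the scatter, so the step expected here is likewise small, a 1.3-fold lower number from compound 3 to compound 4 (0.12 log units; within the scatter). Compound 4 is therefore estimated at 5900 nM, with a likely range from 2500 nM to 14000 nM.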

Compound 4, concentration for 50% growth inhibition: 7100 nM
Beside the measured number, compound 4's estimate is 1.2-fold (0.08 log units) below it; low and high end bracket the measured number.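

In this assay, dimethylamino in place of methoxy gives a 1.1-fold lower number from compound 3 to compound 4 (0.03 log units; within the scatter), so this change stays as small on the hydroxy-bearing core as on the core of compound 1: the same change on two cores in this assay, a 1.3-fold lower number (0.10 log units; within the scatter) from compound 1 to compound 2 and a 1.1-fold lower number (0.03 log units; within the scatter) from compound 3 to compound 4, 1.2-fold (0.07 log units) apart, within the scatter of two such steps. Hydroxy in place of hydrogen gives a 4.2-fold lower number from compound 2 to compound 4 (0.63 log units; beyond the scatter), and this larger step also carries from one core to the other: the same change on two cores in this assay, a 5.0-fold lower number (0.69 log units; beyond the scatter) from compound 1 to compound 3 and a 4.2-fold lower number (0.63 log units; beyond the scatter) from compound 2 to compound 4, 1.2-fold (0.07 log units) apart, within the scatter of two such steps. Together, the four compounds show the two changes behaving the same way on both cores, but they form a single set in one assay and do not show that this would hold on other cores or explain why either step has its size.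

The compounds shown leave open whether a carboxylic acid in place of the hydroxy would give a similar step. They also leave open whether a longer chain, such as ethoxy in place of methoxy, would stay as small.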